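Swapping Bromo for Methoxy on the Shared Core

The source may report more compounds than this note shows. Statements on the series, on what has been measured and on what is new or still open speak of the compounds shown alone.

Three measured compounds share a core carrying a bromo group and differ only in the aryl group attached through an oxygen on a saturated carbon. Compound 1 `O=c1cc(-n2cc(COc3ccccc3Br)nn2)c2cc(Br)ccc2o1` gives 28900 nM in a functional assay on MCF7 cells (Homo sapiens) for antiproliferative activity, read by MTT assay, with a stated time of 48 h; on this read-out higher numbers stand for weaker inhibition and lower numbers for stronger inhibition. Compound 2 `O=c1cc(-n2cc(COc3ccc(F)cc3)nn2)c2cc(Br)ccc2o1` gives 7000 nM in this assay and stands second highest of the three numbers. Compound 3 `COC(=O)c1ccc(OCc2cn(-c3cc(=O)oc4ccc(Br)cc34)nn2)cc1` gives 3130 nM in this assay. The step of a 4.1-fold lower number from compound 1 to compound 2 (0.62 log units; beyond the scatter) and the step of a 2.2-fold lower number from compound 2 to compound 3 (0.35 log units; beyond the scatter) are both modest, and both change the aryl group at the far end while leaving the core untouched.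

Compound 4 `COc1ccc2oc(=O)cc(-n3cc(COc4ccc(F)cc4)nn3)c2c1` keeps the 4-fluorophenyl group of compound 2 and alters the core instead: methoxy in place of bromo on an aromatic carbon. Among the measured compounds shown here, no measured step touches this position, so the two known steps only indicate the scale of what single changes have produced, each of them modest. With nothing pointing in either direction, no step beyond the scatter is expected, although the range must be kept wide. Compound 4 is expected to give 7000 nM in this assay, with a range from 2500 nM to 20000 nM. The expected step is no change at the digits printed from compound 2 to compound 4 (within the scatter).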

Compound 4, half-maximal inhibitory concentration: 8560 nM
Estimate against measurement, compound 4: 1.2-fold (0.09 log units) below; measured number inside the range.
By their numbers in this assay, from the lowest: compound 3; then compounds 2 and 4 (each within the scatter of the next); then compound 1.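

In this assay the core position that carries bromo in compounds 1, 2 and 3 now shows its first measured change, and a 1.2-fold higher number from compound 2 to compound 4 (0.09 log units; within the scatter) stays within the usual scatter, so compounds 2 and 4 cannot be told apart on this read-out. With the 4-fluorophenyl group held constant, methoxy can therefore take the place of bromo on this aromatic carbon without a readable effect on the number, even though methoxy counts a hydrogen-bond acceptor and bromo does not; the two earlier steps, both at the far aryl end, did go beyond the scatter. No measured property of these compounds is available to explain this result.

Methoxy is seen here only alongside the 4-fluorophenyl group, so it remains open whether the same swap would also make no readable difference with the 2-bromophenyl group of compound 1 or the methoxycarbonyl-bearing aryl group of compound 3. Also open is what an amine, a carboxylic acid or a longer alkoxy chain would do at this position on the shared core, since bromo and methoxy are the only two groups shown there.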